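The source may hold more compounds than are shown below. What is called first, only, known or untested is meant among the compounds shown, and "the series" means these compounds.

Of the compounds shown here, two built on one shared core have been tested in a functional assay on Ramos cells (Homo sapiens) for antiproliferative activity, read by CCK-8 assay, with a stated time of 72 h, tested at 40 uM; a higher number here means more inhibition at the concentration tested (going by the name of the read-out), a lower number less inhibition. Compound 1, `CCOC(=O)c1sc(-c2cccc(NC(=O)c3cccc(F)c3)c2)nc1Nc1ccc(N2CCN(C)CC2)cc1`, gives 85.2%. Compound 2, `CCOC(=O)c1sc(-c2cccc(NC(=O)c3ccccc3F)c2)nc1Nc1ccc(N2CCN(C)CC2)cc1`, gives 96.4%. Within the data shown here, the single step between them, a number 11.2 percentage points higher from compound 1 to compound 2 (beyond the scatter), is the whole of the evidence so far, and it leaves compound 2 as the higher of the two numbers by a gap beyond the scatter.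

Compound 3, `CCOC(=O)c1sc(-c2cccc(NC(=O)c3ccc(Cl)cc3)c2)nc1Nc1ccc(N2CCN(C)CC2)cc1`, has not yet been measured. It differs from compound 2 in one place: 4-chlorophenyl in place of 2-fluorophenyl on a carbonyl carbon. Among the measured compounds shown here, only the step from compound 1 to compound 2 bears on this change, as it also exchanged the ring on that carbonyl carbon, and it was modest in size. It shows that the ring on the carbonyl carbon can move the read-out by a modest amount, but it gives no direct sign of what a 4-chlorophenyl does there.

Because compound 2 stands at 96.4%, the highest number shown, a change at the same place is expected to lower the read-out rather than raise it, by about a number 11.4 percentage points lower from compound 2 to compound 3 (beyond the scatter). Compound 3 is therefore estimated at 85%, within a range from 70% to 97%.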

Compound 3, a percentage reported as inhibition, at one concentration (the size of the read-out at that concentration, not a potency): 46.9%
Compound 3: the middle estimate sits 38.1 percentage points above what was measured; the whole stated range lies above it.
By their numbers in this assay, from the lowest: compound 3; then compound 1; then compound 2.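

Putting 4-chlorophenyl on the carbonyl carbon in this assay gives a number 49.5 percentage points lower from compound 2 to compound 3 (beyond the scatter) and a number 38.3 percentage points lower from compound 1 to compound 3 (beyond the scatter), so this position can move the read-out far more than the modest a number 11.2 percentage points higher from compound 1 to compound 2 (beyond the scatter) suggested. A halogen-bearing phenyl is therefore not enough to keep the inhibition high at this concentration: the two fluorophenyl compounds both sit well above compound 3, whose steps to each of them are large and beyond the scatter. Nothing measured here explains why the read-out changes so sharply at this position.

The change from compound 2 to compound 3 swaps fluorine for chlorine and also changes the ring position named in each group, so these compounds cannot show which of the two differences matters; 4-fluorophenyl and 2-chlorophenyl would separate them. Going by these compounds, it also remains open how an unsubstituted phenyl, a 4-methoxyphenyl or a non-aromatic group such as cyclohexyl on the same carbonyl carbon would compare, and whether the low number of compound 3 belongs to chlorine in general or only to this one group.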